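An Alkene Side Chain Regains a Methyl, Gains a Hydroxyl

This account rests on a few compounds, and the source may have more. Where it says the series, first, only, none or still open, it means among the compounds named here.

Compound 1 `C/C=C(/C)C#Cc1ccc(CCC(=O)O)c(F)c1`: in a functional assay on 1321-N1 cells for agonist activity at Free fatty acid receptor 1 (Homo sapiens), read by calcium flux, with a stated time of 0.4 s (a higher number here means that more compound is needed for the effect, a lower number that less compound is needed), compound 1 gives 20.4 nM; 20 nM (2 entries).
Compound 2 `C/C=C(\C)C#Cc1ccc(CCC(=O)O)c(F)c1`: in this assay compound 2 gives 37.2 nM.
Compound 3 `C/C=C/C#Cc1ccc(CCC(=O)O)c(F)c1`: in this assay compound 3 gives 209 nM.

Compound 1 and compound 2 share one structure and differ only in the geometry of the double bond (the fact that compounds 1 and 2 differ only in the configuration as drawn); their two values lie within the usual scatter of each other, and the repeated entries for compound 1 (the several entries of compound 1 in this assay, 20.4 nM; 20 nM (2 entries)) agree closely. Compound 3 stands at the highest of the two single numbers; its nearest neighbour is compound 2, and the step of a 5.6-fold higher number from compound 2 to compound 3 (0.75 log units; beyond the scatter) shows that dropping the methyl from the double-bonded carbon of the side chain costs a modest but clear amount.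

Compound 4 `C/C(C#Cc1ccc(CCC(=O)O)c(F)c1)=C/CO` changes the same side chain again: 3-hydroxy-1-methylprop-1-en-1-yl in place of prop-1-en-1-yl on a triple-bonded carbon. This puts the methyl back on the double-bonded carbon, the very group whose loss drove the step from compound 2 to compound 3, and adds a hydroxyl at the far end of the chain, for which no measured comparison exists. The return of the methyl is expected to reverse most of that earlier step, so the number in this assay is expected to fall by about a 4.6-fold lower number from compound 3 to compound 4 (0.67 log units; beyond the scatter). Compound 4 is therefore estimated at 45 nM, with a likely range from 12 nM to 200 nM.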

Compound 4, half-maximal effective concentration: 427 nM
Beside the measured number, compound 4's estimate is 9.5-fold (0.98 log units) below it; measured number outside the range, above it.
By their numbers in this assay, from the lowest: compound 2; then compound 3; then compound 4.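

The hydroxyl at the far end of the chain is the change that carries a large step here: 3-hydroxy-1-methylprop-1-en-1-yl in place of 1-methylprop-1-en-1-yl on a triple-bonded carbon gives an 11-fold higher number from compound 2 to compound 4 (1.06 log units; beyond the scatter) in this assay. Putting the methyl back therefore does not lower the number when the hydroxyl arrives with it, since the change from prop-1-en-1-yl to 3-hydroxy-1-methylprop-1-en-1-yl gives a 2.0-fold higher number from compound 3 to compound 4 (0.31 log units; beyond the scatter), so the gain linked to the methyl between the two hydroxyl-free side chains does not carry over to this hydroxylated one. The information at hand says nothing about what lies behind these two steps.

The compounds shown leave open how a hydroxyl would read on the prop-1-en-1-yl chain without the methyl, and so how much of the rise belongs to the hydroxyl alone. They also leave open whether the far end of the chain would respond differently to a methoxy group, an amine or a carboxylic acid, and whether the opposite double-bond geometry of the hydroxylated chain would give a different number.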